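Varying the triazole substituent of a bis-benzyloxy lactone core

This account rests on a few compounds, and the source may have more. Where it says the series, first, only, none or still open, it means among the compounds named here.

Measured compounds:
Compound 1 `CCCCc1cn(C[C@H](O)[C@H]2OC(=O)C(OCc3ccccc3)=C2OCc2ccccc2)nn1`: 47500 nM
Compound 2 `O=C1O[C@H]([C@@H](O)Cn2cc(CCCCl)nn2)C(OCc2ccccc2)=C1OCc1ccccc1`: 68500 nM
Compound 3 `Cc1ccc(S(=O)(=O)NCc2cn(C[C@H](O)[C@H]3OC(=O)C(OCc4ccccc4)=C3OCc3ccccc3)nn2)cc1`: 45800 nM

All three share one core and differ only in the group on the five-membered aromatic ring with three nitrogens. In a functional assay on SW-620 cells (Homo sapiens) for antiproliferative activity, read by MTT assay, with a stated time of 72 h (on this read-out lower numbers stand for stronger inhibition and higher numbers for weaker inhibition), compound 3 sits in one cluster with the other two: the steps of a 1.0-fold lower number from compound 1 to compound 3 (0.02 log units; within the scatter) and a 1.5-fold lower number from compound 2 to compound 3 (0.17 log units; within the scatter) stay within the scatter, as does a 1.4-fold higher number from compound 1 to compound 2 (0.16 log units; within the scatter). Compound 4 `COc1ccc(-c2cn(C[C@H](O)[C@H]3OC(=O)C(OCc4ccccc4)=C3OCc3ccccc3)nn2)cc1` carries the change (4-methoxyphenyl in place of (((4-methylphenyl)sulfonyl)amino)methyl on an aromatic carbon). Among the compounds with values here, no measured step swaps in an aromatic group here, so none bears on it directly; the three measured steps only show that changing this position has so far moved nothing beyond the scatter. Compound 4 is therefore expected to give about 50000 nM, between 20000 nM and 125000 nM, a step of a 1.1-fold higher number from compound 3 to compound 4 (0.04 log units; within the scatter).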

Compound 4, half-maximal inhibitory concentration: 58200 nM
Compound 4: the middle estimate sits 1.2-fold (0.07 log units) below what was measured; measured number inside the range.
By their numbers in this assay, from the lowest: compounds 3, 1, 4 and 2 (each within the scatter of the next).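

Compound 4 puts a 4-methoxyphenyl ring straight on the aromatic carbon, and in this assay this too stays within the scatter of the three chain-linked groups (a 1.3-fold higher number from compound 3 to compound 4 (0.10 log units; within the scatter)) (a 1.2-fold lower number from compound 2 to compound 4 (0.07 log units; within the scatter)) (a 1.2-fold higher number from compound 1 to compound 4 (0.09 log units; within the scatter)). So at this position, the numbers so far do not separate an aromatic group from butyl, 3-chloropropyl or (((4-methylphenyl)sulfonyl)amino)methyl. Nothing available explains why the numbers stay together. Still open, from the compounds shown here alone, is whether an amine or a carboxylic acid on this carbon would move the number beyond the scatter. Also open, going by these compounds, is whether changes elsewhere on the shared core would do so.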